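This account rests on a few compounds, and the source may have more. Where it says the series, first, only, none or still open, it means among the compounds named here.

Working notes on the series. In a functional assay on MGC-803 cells (Homo sapiens) for inhibition, read by MTT assay, with a stated time of 48 h (a higher number here means a weaker inhibitor, a lower number a stronger inhibitor), compound 1 `Cc1ccc(NC(=S)NC(=O)c2ccc(OCc3ccccc3F)cc2)cc1-c1nc2ccccc2[nH]1` gives 3070 nM. Compound 2 `O=C(NC(=S)Nc1ccc(Cl)c(-c2nc3ccccc3[nH]2)c1)c1ccc(OCc2ccc(C(F)(F)F)cc2)cc1` gives 5330 nM in this assay. Compound 3 `Cc1ccc(NC(=O)NC(=O)c2ccc(OCc3cccc(Cl)c3)cc2)cc1-c1nc2ccccc2[nH]1` gives 20800 nM in this assay, the highest of the three numbers; its gaps to compound 2 and to compound 1 are both beyond the scatter. Compound 4 `Cc1ccc(NC(=O)NC(=O)c2ccc(OCc3cccc(F)c3)cc2)cc1-c1nc2ccccc2[nH]1` differs from compound 3 by a single change, (fluoro in place of chloro on an aromatic carbon), fluoro in place of chloro on an aromatic carbon. Among the measured compounds shown here, no measured pair isolates this change, so the set gives no direct size for it. Expected is a step of a 1.2-fold higher number from compound 3 to compound 4 (0.08 log units; within the scatter) that stays within the scatter, with no clear direction. Compound 4 is estimated at 25000 nM in this assay, within a range from 10000 nM to 60000 nM.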

Compound 4, half-maximal inhibitory concentration: 44800 nM
Estimate against measurement, compound 4: 1.8-fold (0.25 log units) below; the measured number falls inside the stated range.
By their numbers in this assay, from the lowest: compounds 1 and 2 (each within the scatter of the next); then compound 3; then compound 4.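

In this assay, among the compounds shown here, the change of fluoro in place of chloro gives a 2.2-fold higher number from compound 3 to compound 4 (0.33 log units; beyond the scatter) as the first step that isolates a single change. At this place, on the benzyl ring, the choice of halogen therefore registers in the read-out, modestly and in the direction of a weaker inhibitor. No available measurement bears on the reason for this step. Still open, as far as these compounds go, is whether a methoxy group or an amine at this place would give a lower number than either halogen. Also open, from the compounds shown here alone, is whether the same change holds with the thiocarbonyl linker of compound 1.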